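A few compounds are considered here, and "the series" means these few. Any claim that something is new, unique, unknown or untested is made for them only; others in the source may bear on it.

Measured in this series:

compound 1 `CNC(=O)c1cccc(Cn2nc(C)c(NC(=O)c3ccc(COc4ccccc4)cc3)c2C)c1` — 6200 nM
compound 2 `CNC(=O)c1cccc(Cn2nc(C)c(NC(=O)c3ccc(COC4CCCCC4)cc3)c2C)c1` — 14000 nM
compound 3 `CNC(=O)c1cccc(Cn2nc(C)c(NC(=O)c3ccc(COc4ccc(C)cc4)cc3)c2C)c1` — 2600 nM

In a functional assay on MIA PaCa-2 cells (Homo sapiens) for antiproliferative activity, read by MTT assay, with a stated time of 72 h (on this read-out lower numbers stand for an effect already at smaller amounts and higher numbers for an effect only at larger amounts of compound), compound 3 gives the lowest number of the three. The step of a 2.4-fold lower number from compound 1 to compound 3 (0.38 log units; beyond the scatter) separates it from compound 1, and the step of a 5.4-fold lower number from compound 2 to compound 3 (0.73 log units; beyond the scatter) from compound 2, both beyond the scatter. Compound 2 itself sits beyond compound 1 by a 2.3-fold higher number from compound 1 to compound 2 (0.35 log units; beyond the scatter).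

Compound 4 `CNC(=O)c1cccc(Cn2nc(C)c(NC(=O)c3ccc(COc4cccc(OC)c4)cc3)c2C)c1` differs from compound 3 in one place: 3-methoxyphenyl in place of 4-methylphenyl on an oxygen on a saturated carbon. Among the compounds with values here, two measured steps bear on this. The step of a 2.4-fold lower number from compound 1 to compound 3 (0.38 log units; beyond the scatter) shows that the methyl on the aromatic carbon accounts for a modest gain over the bare phenyl of compound 1; removing it in compound 4 is expected to give that gain back. The step of a 5.4-fold lower number from compound 2 to compound 3 (0.73 log units; beyond the scatter) shows that an aromatic ring here is favoured over cyclohexyl, and compound 4 keeps an aromatic ring. Within the data shown here, no measured compound carries a methoxy on this ring, so its own contribution is untested. Compound 4 is therefore expected to land near compound 1, a modest step of a 1.9-fold higher number from compound 3 to compound 4 (0.28 log units; within the scatter) upward from compound 3, with an estimate of 5000 nM and a range from 1800 nM to 14000 nM.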

Compound 4, half-maximal effective concentration: 6200 nM
The estimate for compound 4 lay 1.2-fold (0.09 log units) below the measured number; low and high end bracket the measured number.
By their numbers in this assay, from the lowest: compound 3; then compounds 1 and 4 (each within the scatter of the next); then compound 2.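

In this assay, 3-methoxyphenyl on this oxygen reads as the unsubstituted phenyl does, no change at the digits printed from compound 1 to compound 4 (within the scatter), so not every added group on this ring gives a lower number, and the 4-methylphenyl of compound 3 keeps its edge, a 2.4-fold higher number from compound 3 to compound 4 (0.38 log units; beyond the scatter). A second substituted aromatic ring also stands clear of cyclohexyl, a 2.3-fold lower number from compound 2 to compound 4 (0.35 log units; beyond the scatter), so the advantage over cyclohexyl now holds for all three aromatic rings shown, with no compound against it. No measured evidence at hand accounts for these steps.

Still open, on these data alone, is whether the lower number of compound 3 follows the methyl group or its place on the ring, which a 3-methylphenyl or a 4-methoxyphenyl group would separate. Also open, as far as these compounds go, is how a dimethylamino group or a carboxylic acid on this ring would read.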